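Compound 3: trichlorophenyl in place of dimethylphenyl

The compounds below may be only part of what the source reports. "The series", "measured", "known", "first", "only" and "open" are said of these compounds alone.

Measured so far in a functional assay on A549 cells (Homo sapiens) for antiproliferative activity, read by MTT assay, with a stated time of 72 h; on this read-out higher numbers stand for weaker inhibition and lower numbers for stronger inhibition:
Compound 1 `NC1=NC2(CCOCC2)N(OCCCOc2cccc(Cl)c2Cl)C(N)=N1`: 100 nM
Compound 2 `Cc1cc(C)cc(OCCCON2C(N)=NC(N)=NC23CCOCC3)c1`: 710 nM

Among the measured compounds shown here, of these two numbers, the higher belongs to compound 2 at 710 nM, and its only neighbour is compound 1 at 100 nM. The unmeasured compound 3 `NC1=NC2(CCOCC2)N(OCCCOc2cc(Cl)c(Cl)cc2Cl)C(N)=N1` departs from compound 2 in one place: 2,4,5-trichlorophenyl in place of 3,5-dimethylphenyl on an oxygen on a saturated carbon. In words, 2,4,5-trichlorophenyl stands in place of 3,5-dimethylphenyl on an oxygen on a saturated carbon.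

For the measured compounds named here, one measured step bears on this change: a 7.1-fold higher number from compound 1 to compound 2 (0.85 log units; beyond the scatter). There, 3,5-dimethylphenyl replaced 2,3-dichlorophenyl at the same place. The step to compound 3 runs the other way, from the same 3,5-dimethylphenyl to a phenyl that also carries chlorine. Going by the values given here, a step of similar size is therefore expected in this assay, towards a lower number, though no trichlorophenyl compound has yet been measured and this single step is thin support. The expected change is a 5.9-fold lower number from compound 2 to compound 3 (0.77 log units; beyond the scatter). For compound 3 the estimated value is 120 nM, with an expected range of 40 nM to 400 nM.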

Compound 3, half-maximal inhibitory concentration: 680 nM
Compound 3: middle estimate off by 5.7-fold (0.75 log units), on the low side; the whole stated range lies below it.
By their numbers in this assay, from the lowest: compound 1; then compounds 3 and 2 (each within the scatter of the next).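

In this assay, 2,4,5-trichlorophenyl in place of 3,5-dimethylphenyl on an oxygen on a saturated carbon gives a 1.0-fold lower number from compound 2 to compound 3 (0.02 log units; within the scatter), so this assay does not separate these two groups at this place. The presence of chlorine on the phenyl therefore does not by itself go with the lower number: 2,4,5-trichlorophenyl in place of 2,3-dichlorophenyl gives a 6.8-fold higher number from compound 1 to compound 3 (0.83 log units; beyond the scatter), and compound 3 goes against any reading that ties the lower number to chlorine in general. Among the three compounds, only compound 1, with its 2,3-dichlorophenyl, stands apart from the others in this assay, and nothing available here explains why the two chlorine-bearing groups differ in this way.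

The compounds shown leave open which feature of the 2,3-dichlorophenyl group goes with the lower number, since neither a phenyl with a single chlorine nor an unsubstituted phenyl appears among them. They also leave open how a 2,3-dimethylphenyl, a methoxyphenyl or a pyridine ring would compare at this place, and whether a longer chain would alter the gap between these groups.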